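The source may report more compounds than this note shows. Statements on the series, on what has been measured and on what is new or still open speak of the compounds shown alone.

In an assay on CHO cells for displacement of a labelled ligand from prostaglandin E2 receptor EP2 subtype (Mus musculus), read by scintillation counting, with a stated time of 60 min (on this read-out lower numbers stand for stronger inhibition and higher numbers for weaker inhibition), compound 1 `O=C(O)c1csc(SCCN2C(=O)CC[C@@H]2/C=C/[C@@H](O)Cc2cccc(-c3ccc(Cl)cc3)c2)n1` gives 1.7 nM, and compound 2 `Cc1ccc2oc(-c3cccc(C[C@H](O)/C=C/[C@H]4CCC(=O)N4CCSc4nc(C(=O)O)cs4)c3)nc2c1` gives 21 nM. Among the measured compounds shown here, compound 2 thus stands at the higher of the two numbers, and the only measured step, a 12-fold higher number from compound 1 to compound 2 (1.09 log units; beyond the scatter), separates the pair. Compound 3 `Cc1cccc2oc(-c3cccc(C[C@H](O)/C=C/[C@H]4CCC(=O)N4CCSc4nc(C(=O)O)cs4)c3)nc12` has the same atoms as compound 2 joined differently: 4-methyl-1,3-benzoxazol-2-yl in place of 5-methyl-1,3-benzoxazol-2-yl on an aromatic carbon. For the measured compounds named here, no measured step involves this change. The step from compound 1 to compound 2 exchanged the whole 4-chlorophenyl for the 5-methyl-1,3-benzoxazol-2-yl group and was large, but it says nothing about shifting the methyl within that group once it is in place. Going by the values given here, with no measured step bearing on the change, and the two structures otherwise identical, no step beyond the scatter is expected in this assay, in either direction. The expected step, a 1.2-fold higher number from compound 2 to compound 3 (0.08 log units; within the scatter), is accordingly small. Compound 3 is therefore estimated at 25 nM in this assay, with a range from 8 nM to 80 nM.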

Compound 3, inhibition constant: 22 nM
Estimate against measurement, compound 3: 1.1-fold (0.06 log units) above; measured number inside the range.
By their numbers in this assay, from the lowest: compound 1; then compounds 2 and 3 (each within the scatter of the next).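

In this assay, exchanging 5-methyl-1,3-benzoxazol-2-yl for 4-methyl-1,3-benzoxazol-2-yl, on an aromatic carbon meta to a large group, gives a 1.0-fold higher number from compound 2 to compound 3 (0.02 log units; within the scatter), so these two placements of the methyl cannot be told apart in this assay, which the earlier pair could not show. The exchange of 4-chlorophenyl for a methylated benzoxazolyl group now has a second example, a 13-fold higher number from compound 1 to compound 3 (1.11 log units; beyond the scatter), so the large step seen earlier, a 12-fold higher number from compound 1 to compound 2 (1.09 log units; beyond the scatter), does not rest on the 5-methyl placement alone. No measurement is at hand that would explain either the large steps or the absence of a step between the two methyl placements.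

The compounds shown leave open how the unsubstituted 1,3-benzoxazol-2-yl group, or a chlorine or methoxy group in place of the methyl, would read in this assay. They also leave open whether the two methyl placements would remain indistinguishable on any other receptor subtype.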